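Propylamino Replaces Methoxy on a Flat Series

The source may report more compounds than this note shows. Statements on the series, on what has been measured and on what is new or still open speak of the compounds shown alone.

Three compounds share one core and differ only in the group on an aromatic carbon of a six-membered aromatic ring with 2 nitrogen. Compound 1 `Nc1ncnc2c1ncn2C[C@@H]1C[C@H](CO)c2ccccc21` carries an amino group there, and in a functional assay on MOLT-4 cells (Homo sapiens) (a higher number here means a weaker inhibitor, a lower number a stronger inhibitor), compound 1 gives 24 ug/mL. Compound 2 `OC[C@H]1C[C@@H](Cn2cnc3c(O)ncnc32)c2ccccc21` carries a hydroxy group, and in this assay compound 2 gives 24 ug/mL. Compound 3 `COc1ncnc2c1ncn2C[C@@H]1C[C@H](CO)c2ccccc21` carries a methoxy group, and in this assay compound 3 gives 24 ug/mL. Compound 3 therefore stands level with compounds 1 and 2: the steps of no change at the digits printed from compound 1 to compound 3 (within the scatter) and no change at the digits printed from compound 2 to compound 3 (within the scatter) both lie within the scatter, as does no change at the digits printed from compound 1 to compound 2 (within the scatter). The next compound, compound 4 `CCCNc1ncnc2c1ncn2C[C@@H]1C[C@H](CO)c2ccccc21`, differs from compound 3 at that same carbon: propylamino in place of methoxy on an aromatic carbon. Among the measured compounds shown here, no measured step introduces a propylamino group, but the three replacements already made there, hydroxy in place of amino, methoxy in place of amino and methyl in place of hydrogen on the oxygen, left this assay unmoved. On that basis compound 4 is expected to show no step beyond the scatter, no change at the digits printed from compound 3 to compound 4 (within the scatter). The estimate for compound 4 in this assay is 24 ug/mL, with a range from 8 ug/mL to 60 ug/mL.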

Compound 4, half-maximal inhibitory concentration: 24 ug/mL
Estimate against measurement, compound 4: no gap at the digits printed; the range from low to high includes it.
By their numbers in this assay, from the lowest: compounds 1, 2, 3 and 4 (each within the scatter of the next).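

Compound 4 puts a longer chain on this carbon than any earlier compound, propylamino with 4 heavy atoms and 1 hydrogen-bond donor in place of methoxy with 2 heavy atoms and none, yet this assay shows no change at the digits printed from compound 3 to compound 4 (within the scatter) for this change. The comparisons with the other two compounds read the same, no change at the digits printed from compound 2 to compound 4 (within the scatter) against the hydroxy compound and no change at the digits printed from compound 1 to compound 4 (within the scatter) for propyl in place of hydrogen on the nitrogen, so alkylating that nitrogen also leaves the read-out level across these four compounds. Nothing at hand accounts for this flatness.

From the compounds shown here alone, whether the level read-out holds for a carboxylic acid, a piperidine or an octylamino chain on this carbon remains open. Going by these compounds, all four compounds also keep the shared core and its hydroxymethyl group, so the effect of an amine or a carboxylic acid in place of that hydroxymethyl is unknown too.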